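Morpholin-4-yl in Place of Amino: Expected Paw Edema Inhibition

The source may report more compounds than this note shows. Statements on the series, on what has been measured and on what is new or still open speak of the compounds shown alone.

Compound 1 `COc1cc2c(cc1OC)C(CC(N)=O)CC2` carries an amino group on a carbonyl carbon whose other neighbour is a saturated chain carbon. Within the data shown here, in a functional assay on the whole organism (strain Wistar) for inhibition, with Rattus norvegicus as the target, read by paw edema, with stated times of 60 min and 24 h, at a dose of 100 mg/kg by the oral route (a higher number here means more inhibition at the dose given (going by the name of the read-out), a lower number less inhibition), compound 1 gives 26.7%, the lowest of the three numbers known so far. Compound 2 `CCCCNC(=O)CC1CCc2cc(OC)c(OC)cc21` gives 36.7%, and the step of a number 10 percentage points higher from compound 1 to compound 2 (within the scatter) stays within the scatter. Compound 3 `COc1cc2c(cc1OC)C(CC(=O)NC1CCCCC1)CC2` gives 53.3% after a number 26.6 percentage points higher from compound 1 to compound 3 (beyond the scatter), and from compound 2 the step of a number 16.6 percentage points higher from compound 2 to compound 3 (beyond the scatter) points the same way. Compound 4 `COc1cc2c(cc1OC)C(CC(=O)N1CCOCC1)CC2` has not yet been measured; it differs from compound 1 by morpholin-4-yl in place of amino on a carbonyl carbon. Both measured steps that start from compound 1 bear on this change, since each also enlarges what sits on the amide-type nitrogen, and the gain with a six-membered ring, a number 26.6 percentage points higher from compound 1 to compound 3 (beyond the scatter), was the larger of the two. Compound 4 is therefore expected to show a modest rise, a number 15.3 percentage points higher from compound 1 to compound 4 (beyond the scatter), in this assay. The estimate for compound 4 is 42%, with a range from 25% to 60%.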

Compound 4, a percentage reported as inhibition, in the whole organism at one dose (the size of the read-out at that dose, not a potency): 23.3%
Compound 4: the middle estimate sits 18.7 percentage points above what was measured, outside the stated range (below it).
By their numbers in this assay, from the lowest: compounds 4, 1 and 2 (each within the scatter of the next, the first and the last beyond it); then compound 3.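

In this assay a six-membered ring on the carbonyl carbon does not by itself bring a gain: morpholin-4-yl in place of amino gives a number 3.4 percentage points lower from compound 1 to compound 4 (within the scatter) and so leaves the number where it was. The same group in place of cyclohexylamino gives a number 30 percentage points lower from compound 3 to compound 4 (beyond the scatter) and in place of butylamino gives a number 13.4 percentage points lower from compound 2 to compound 4 (beyond the scatter) so the number of heavy atoms in this group does not alone set the inhibition among these compounds. Nothing at hand accounts for the difference between the two six-membered rings.

Cyclohexylamino and morpholin-4-yl differ both in the amide hydrogen and in the ring oxygen, and the compounds shown do not separate the two. A piperidin-1-yl group on the same carbonyl carbon, or a tetrahydropyran-4-ylamino group, would each change only one of them.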